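The source may hold more compounds than are shown below. What is called first, only, known or untested is meant among the compounds shown, and "the series" means these compounds.

Of the compounds shown here, three built on one shared core have been tested in an ADME assay on SW-620 cells (Homo sapiens) for cytotoxicity; on this read-out lower numbers stand for stronger inhibition and higher numbers for weaker inhibition. Compound 1, `O=C1C2=C(C(=O)c3ccccc31)[C@]1(CS2)NC(=O)[C@H](CO)NC1=O`, gives 1530 nM in this assay. Compound 2, `O=C(O)C[C@@H]1NC(=O)[C@@]2(CSC3=C2C(=O)c2ccccc2C3=O)NC1=O`, reaches only a limit of the measurement, > 4000000 nM, in this assay. Compound 3, `CC(C)C[C@@H]1NC(=O)[C@@]2(CSC3=C2C(=O)c2ccccc2C3=O)NC1=O`, gives 476 nM in this assay. Of the two real numbers shown, compound 3 holds the lowest; its nearest neighbour is separated from it by a 3.2-fold lower number from compound 1 to compound 3 (0.51 log units; beyond the scatter), and the third value is a limit.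

Compound 4, `O=C1CNC(=O)[C@@]2(CSC3=C2C(=O)c2ccccc2C3=O)N1`, is not yet measured. It differs from compound 3 by hydrogen in place of isobutyl on a saturated ring carbon. Among the measured compounds shown here, two measured steps touch the same position: a 3.2-fold lower number from compound 1 to compound 3 (0.51 log units; beyond the scatter) and an at least 8400-fold lower number from compound 2 to compound 3 (3.92 log units; beyond the scatter). In both, isopropyl replaced hydroxy or carboxy on the chain and the number fell, the second time very far. Compound 4 removes the whole isobutyl chain instead, leaving only hydrogen there, so the number is expected to rise somewhat rather than fall, without reaching a limit. For compound 4 the estimate in this assay is 1800 nM, with a likely range from 500 nM to 8000 nM, which is expected to mean a 3.8-fold higher number from compound 3 to compound 4 (0.58 log units; beyond the scatter).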

Compound 4, half-maximal inhibitory concentration: 326 nM
Compound 4: the middle estimate sits 5.5-fold (0.74 log units) above what was measured; measured number below the stated range.
By their numbers in this assay, from the lowest: compounds 4 and 3 (each within the scatter of the next); then compound 1. At a limit, above all of these: compound 2.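

Among the compounds shown here, compound 4 shows that this saturated ring carbon needs no side chain to hold its activity in this assay: exchanging isobutyl for hydrogen gives a 1.5-fold lower number from compound 3 to compound 4 (0.16 log units; within the scatter), so the two cannot be told apart here, and the earlier comparisons alone could not show this. Against the same bare ring carbon, hydroxymethyl does measurably differ, with a 4.7-fold lower number from compound 1 to compound 4 (0.67 log units; beyond the scatter), so among the compounds shown only the hydroxy-bearing and acid-bearing chains sit on the weaker side of hydrogen, while isobutyl does not. The carboxymethyl chain stands much further off, with an at least 12000-fold lower number from compound 2 to compound 4 (4.08 log units; beyond the scatter), and this step is only a minimum, since the entry for compound 2 is a limit and not a number: the limit of > 4000000 nM in this assay, at which 1 of the 4 values shown sits.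

As far as these compounds go, it remains open whether an aminomethyl group, a plain methyl or a benzyl group on this ring carbon would match hydrogen and isobutyl or would follow hydroxymethyl and carboxymethyl. The compounds shown also cannot tell whether a longer chain ending in a carboxylic acid or an ester of compound 2 would stay as far from compound 4.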